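The source may hold more compounds than are shown below. What is called first, only, known or untested is meant among the compounds shown, and "the series" means these compounds.

Measured compounds in a functional assay on MCF7 cells (Homo sapiens) for antiproliferative activity, read by MTT assay, with a stated time of 72 h; a higher number here means a weaker inhibitor, a lower number a stronger inhibitor:

compound 1 `Cc1cc(N(C)C)nc2ccc(NC(=O)c3ccc(Cl)c(Cl)c3)cc12`, 33300 nM
compound 2 `CCN1CCN(c2cc(C)c3cc(NC(=O)c4cccnc4)ccc3n2)CC1`, 26600 nM
compound 3 `CNc1cc(C)c2cc(NC(=O)c3ccc(Cl)c(Cl)c3)ccc2n1`, 2520 nM

Compound 2 stands second highest of the three numbers; against compound 1 it lies within the scatter, while compound 3 sits well lower. For the measured compounds named here, the one measured step, a 13-fold lower number from compound 1 to compound 3 (1.12 log units; beyond the scatter), concerns hydrogen in place of methyl on a nitrogen on an aromatic ring and does not touch the amide aryl.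

Compound 4 `CCN1CCN(c2cc(C)c3cc(NC(=O)c4ccc(Br)cc4)ccc3n2)CC1` differs from compound 2 by 4-bromophenyl in place of pyridin-3-yl on a carbonyl carbon. Going by the values given here, no measured step bears on this change; compounds 1 and 3 carry a different aryl and differ from compound 2 in a second place as well, so nothing can be read from them. In this assay the step of a 1.3-fold lower number from compound 2 to compound 4 (0.12 log units; within the scatter) is therefore expected to stay near the scatter. Compound 4 is estimated at 20000 nM, range 6000 nM to 60000 nM.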

Compound 4, half-maximal inhibitory concentration: 5940 nM
Compound 4: middle estimate off by 3.4-fold (0.53 log units), on the high side; the whole stated range lies above it.
By their numbers in this assay, from the lowest: compound 3; then compound 4; then compounds 2 and 1 (each within the scatter of the next).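

In this assay, for the compounds shown here, the group on a carbonyl carbon is a position that can move the number: a 4.5-fold lower number from compound 2 to compound 4 (0.65 log units; beyond the scatter) is the first measured step here and lies beyond the scatter. The change replaces a ring with one hetero atom by a carbon-only ring carrying bromine, and this single pair cannot separate those two parts. Nothing available explains the step.

Open, from the compounds shown here alone, is whether the bromine or the loss of the ring nitrogen carries the step; plain phenyl on the same carbonyl would separate them. Also open, going by these compounds, is whether 4-methoxyphenyl or 4-aminophenyl there behaves like 4-bromophenyl.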